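Removing a Drawn Configuration: From Compound 3 to Compound 4

The compounds below may be only part of what the source reports. "The series", "measured", "known", "first", "only" and "open" are said of these compounds alone.

Compound 1, `C/C(=N\NC(=S)Nc1cccc(I)c1)c1ccccn1`, in a functional assay on U-87MG ATCC cells (Homo sapiens) for cytotoxicity, read by MTT assay, with a stated time of 48 h; a higher number here means a weaker inhibitor, a lower number a stronger inhibitor: 84 nM
Compound 2, `CC(=NNC(=S)Nc1ccc(Cl)cc1)c1ccccn1`: 1.7 nM
Compound 3, `C/C(=N\NC(=S)Nc1cccc([N+](=O)[O-])c1)c1ccccn1`: 69 nM

Among the three measured compounds, compound 3 gives the second highest number in this assay. Its nearest neighbour is compound 1, whose number lies within the usual scatter of that of compound 3, so no order between the two can be read from the data. Its furthest neighbour is compound 2, whose number is lower by a margin well beyond the scatter. Within the data shown here, the only measured step in which one place changes is the one from compound 1 to compound 3, where nitro replaces iodo on an aromatic carbon: a 1.2-fold lower number from compound 1 to compound 3 (0.09 log units; within the scatter).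

Compound 4, `CC(=NNC(=S)Nc1cccc([N+](=O)[O-])c1)c1ccccn1`, is the next compound to be measured. Its difference from compound 3 is the two compounds have the same atoms and bonds; at least one stereo element is drawn with a configuration in one of them and without one in the other: 1 of 1 stereo elements differ; a double bond is drawn E in compound 3 and without a configuration in compound 4. Among the measured compounds shown here, no measured step concerns a change of this kind; the nitro-for-iodo step involves a real exchange of groups, which this one does not. Since the two drawings hold the same atoms and bonds, no step beyond the scatter is expected in this assay. Compound 4 is therefore estimated at 69 nM, with a range from 30 nM to 160 nM. The step from compound 3 that this estimate means is no change at the digits printed from compound 3 to compound 4 (within the scatter), and it is expected to fall within the scatter.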

Compound 4, half-maximal inhibitory concentration: 69 nM
Beside the measured number, compound 4's estimate shows no gap at the digits printed, within the range that was stated.
By their numbers in this assay, from the lowest: compound 2; then compounds 3, 4 and 1 (each within the scatter of the next).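

There is no change at the digits printed from compound 3 to compound 4 (within the scatter) in this assay and so, for this nitro compound, whether the double bond is drawn E or left undefined makes no readable difference to the number. Among these compounds, the earlier compounds could not show this: the one step among them showed a 1.2-fold lower number from compound 1 to compound 3 (0.09 log units; within the scatter) and concerned an exchange of iodo for nitro on an aromatic carbon, with the E double bond drawn at both ends of that step. The new step involves no exchange of groups at all, and only one thing separates the two entries: the fact that one of compounds 3 and 4 is drawn with a defined configuration and the other without, at the place where they differ.

The drawing alone leaves open whether compound 4 is a single form or a mixture, what a double bond explicitly drawn Z would give, and whether the iodo compound 1 would behave in the same way if drawn without a configuration. Also open, from the compounds shown here alone, is what an amine or a carboxylic acid would give on the aromatic carbon that carries the nitro group in compound 3.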